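Swapping Chloro for Bromo in Compound 4

The source may hold more compounds than are shown below. What is called first, only, known or untested is meant among the compounds shown, and "the series" means these compounds.

Compound 3 `C=CC(=O)Nc1cccc(NC(=O)CSc2nc(Nc3cccc(Cl)c3)c3ccccc3n2)c1` stands second highest of the three numbers measured in a functional assay on NCI-H1975 cells (Homo sapiens) for inhibition, read by MTT assay, with a stated time of 72 h (on this read-out lower numbers stand for stronger inhibition and higher numbers for weaker inhibition), where compound 3 gives 9460 nM. Its closest neighbour is compound 1 `C=CC(=O)Nc1cccc(NC(=O)CSc2nc(Nc3ccccc3C)c3ccccc3n2)c1`, which in this assay gives 9920 nM; a 1.0-fold lower number from compound 1 to compound 3 (0.02 log units; within the scatter). The lowest number belongs to compound 2 `C=CC(=O)Nc1cccc(NC(=O)CSc2nc(Nc3cccc(F)c3)c3ccccc3n2)c1`, which in this assay gives 2030 nM; a 4.7-fold higher number from compound 2 to compound 3 (0.67 log units; beyond the scatter).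

Compound 4 `C=CC(=O)Nc1cccc(NC(=O)CSc2nc(Nc3cccc(Br)c3)c3ccccc3n2)c1` is derived from compound 3 by a single change: bromo in place of chloro on an aromatic carbon. For the measured compounds named here, no measured pair shows this particular exchange. Going by the values given here, the one halogen-for-halogen step available is a 4.7-fold higher number from compound 2 to compound 3 (0.67 log units; beyond the scatter), and the remaining step, a 4.9-fold lower number from compound 1 to compound 2 (0.69 log units; beyond the scatter), changes both the group and its place on the ring, so neither bears directly on a chloro-to-bromo swap at the same place. With the halogen kept on the same aromatic carbon and only its identity shifted, the change in this assay is expected to be a 1.1-fold lower number from compound 3 to compound 4 (0.02 log units; within the scatter), not clearly beyond the scatter in either direction. Compound 4 is therefore estimated in this assay at 9000 nM, with a range from 3000 nM to 27000 nM.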

Compound 4, half-maximal inhibitory concentration: 12100 nM
Compound 4: the middle estimate sits 1.3-fold (0.13 log units) below what was measured; the measured number falls inside the stated range.
By their numbers in this assay, from the lowest: compound 2; then compounds 3, 1 and 4 (each within the scatter of the next).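

In this assay the 3-bromophenyl group could not be told apart from the 3-chlorophenyl group, with a 1.3-fold higher number from compound 3 to compound 4 (0.11 log units; within the scatter) as the step, so at this place on the ring the two heavier halogens give the same picture. The gap to the fluoro compound now holds for two halogens rather than one, with a 6.0-fold higher number from compound 2 to compound 4 (0.78 log units; beyond the scatter) as the step, which leaves compound 2 the most potent of the four and fluoro the only halogen shown here that stands apart. The bromo compound also stays level with the 2-methylphenyl compound, with a 1.2-fold higher number from compound 1 to compound 4 (0.09 log units; within the scatter) as the step, so three of the four compounds sit together within the scatter and compound 2 alone departs from them.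

The evidence at hand offers no account of why fluoro alone differs. Still open, going by these compounds, is whether an amine, a methoxy group or a nitrile on this same aromatic carbon would fall with compound 2 or with the other three, and whether fluoro would keep its lead on another carbon of the ring.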